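Swapping Trifluoromethyl for Chloro on the Benzyl Ring

The compounds below may be only part of what the source reports. "The series", "measured", "known", "first", "only" and "open" are said of these compounds alone.

Compound 1, `C/C(C#Cc1ccccc1)=N\N/C(N)=N/S(=O)(=O)c1cc(C)c(Cl)cc1SCc1ccccc1C(F)(F)F`: 19000 nM in a functional assay on MCF7 cells (Homo sapiens) for antiproliferative activity, read by MTT assay, with a stated time of 72 h; on this read-out higher numbers stand for weaker inhibition and lower numbers for stronger inhibition
Compound 2, `C/C(C#Cc1ccccc1)=N\N/C(N)=N/S(=O)(=O)c1cc(C)c(Cl)cc1SCc1cccc(C(F)(F)F)c1`: 20000 nM in this assay

Compound 2 sits alongside compound 1 on the numbers shown: the single measured step, a 1.1-fold higher number from compound 1 to compound 2 (0.02 log units; within the scatter), lies within the scatter, so the two compounds cannot be separated in this assay. Compound 3, `C/C(C#Cc1ccccc1)=N\N/C(N)=N/S(=O)(=O)c1cc(C)c(Cl)cc1SCc1cccc(Cl)c1`, is not yet measured. It differs from compound 2 in one place: chloro in place of trifluoromethyl on an aromatic carbon. Going by the values given here, no measured step replaces trifluoromethyl with chloro. Among the compounds with values here, the only step available, a 1.1-fold higher number from compound 1 to compound 2 (0.02 log units; within the scatter), moves the trifluoromethyl from one position of the benzyl ring to another and leaves the number essentially where it was. That step bears on the present change only indirectly, in showing that alterations to the benzyl substituent have so far not shifted the read-out beyond the scatter; it gives no direct guide to the size or direction of a chloro-for-trifluoromethyl exchange. On this basis the expected step in this assay is no change at the digits printed from compound 2 to compound 3 (within the scatter), within the scatter. Compound 3 is estimated at 20000 nM, with a range from 8000 nM to 50000 nM.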

Compound 3, half-maximal inhibitory concentration: 80000 nM
Compound 3: middle estimate off by 4.0-fold (0.60 log units), on the low side, outside the stated range (above it).
By their numbers in this assay, from the lowest: compounds 1 and 2 (each within the scatter of the next); then compound 3.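

In this assay, the benzyl substituent can shift the read-out: replacing 3-(trifluoromethyl)benzyl with 3-chlorobenzyl gives a 4.0-fold higher number from compound 2 to compound 3 (0.60 log units; beyond the scatter), toward weaker inhibition, a move the change of trifluoromethyl position had not produced. The comparison with the 2-(trifluoromethyl)phenyl of compound 1 points the same way, with a 4.2-fold higher number from compound 1 to compound 3 (0.62 log units; beyond the scatter), so compound 3 stands apart from both trifluoromethyl compounds, which themselves cannot be separated. Nothing available accounts for this difference between trifluoromethyl and chloro at this place.

The compounds shown leave open whether the weaker inhibition is particular to chloro or would also appear with fluoro, methyl, methoxy or a bare hydrogen on the same aromatic carbon. They also leave open whether chloro, like trifluoromethyl, would give an indistinguishable number when placed where the trifluoromethyl of compound 1 sits, and whether a larger group such as a phenyl ring or a carboxylic acid would move the number further in either direction.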